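The source may hold more compounds than are shown below. What is called first, only, known or untested is meant among the compounds shown, and "the series" means these compounds.

For the measured compounds named here, compound 1 `CCc1ccc(NS(=O)(=O)c2ccc(N3CCNC3=O)cc2)cc1` is the only compound with a definite number in a functional assay on M21 cells (Homo sapiens) for antiproliferative activity, read by sulforhodamine B assay, with a stated time of 48 h; a lower number here means a stronger inhibitor, a higher number a weaker inhibitor: compound 1 gives 480 nM. Compound 2 `CC(C)Cc1ccc(NS(=O)(=O)c2ccc(N3CCNC3=O)cc2)cc1` differs from it by isopropyl in place of methyl on a saturated chain carbon bound to an aromatic carbon. In this assay compound 2 reaches only the limit > 1000 nM. The step of an at least 2.0-fold higher number from compound 1 to compound 2 (0.31 log units; beyond the scatter) is therefore known only as a bound, set by the limit of > 1000 nM in this assay, at which 1 of the 2 values shown sits. Compound 3 `Cc1ccc(NS(=O)(=O)c2ccc(N3CCNC3=O)cc2)c(C)c1` keeps the same atoms, joined differently: 2,4-dimethylphenyl in place of 4-ethylphenyl on a sulfonamide nitrogen. Going by the values given here, no measured step rearranges methyl groups in this way; the one step known, which extended the chain, gave a weaker compound. The expected step of a 1.4-fold higher number from compound 1 to compound 3 (0.13 log units; within the scatter) is therefore small, close to the scatter, leaning toward a weaker compound. Compound 3 is estimated to give 650 nM, with a likely range from 250 nM to 1600 nM.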

Compound 3, half-maximal inhibitory concentration: 150 nM
For compound 3 the middle estimate is 4.3-fold (0.64 log units) above the measured one; the whole stated range lies above it.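

In this assay, rearranging the same carbon atoms on the sulfonamide nitrogen, from 4-ethylphenyl to 2,4-dimethylphenyl, gives a 3.2-fold lower number from compound 1 to compound 3 (0.51 log units; beyond the scatter). The two groups match in heavy atoms, in their six-membered aromatic ring and in having no hydrogen-bond donors or acceptors, so these counts alone do not settle the activity; the way the carbons are arranged on the ring matters as well. The earlier change at this position, to compound 2, gave a weaker compound, whereas this one shows that the same position can also yield a stronger compound.

As far as these compounds go, whether a single methyl group on the ring would be enough, or whether a chlorine or a methoxy group could replace a methyl, stays open. The size of the step to compound 2 also remains unsettled: the limit of > 1000 nM in this assay, at which 1 of the 3 values shown sits.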